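Removing the Methyl from the Ring Nitrogen of Compound 1

This account rests on a few compounds, and the source may have more. Where it says the series, first, only, none or still open, it means among the compounds named here.

Measured so far:
- compound 1, `COc1cc(C(=O)NS(=O)(=O)c2ccccc2)ccc1Cc1cn(C)c2ccc(NC(=O)OC3CCCC3)cc12`: 0.8 nM
- compound 2, `COc1cc(C(=O)NS(=O)(=O)c2ccccc2Cl)ccc1Cc1nn(C)c2ccc(NC(=O)OC3CCCC3)cc12`: 0.3 nM
- compound 3, `COc1cc(C(=O)NS(=O)(=O)c2ccccc2C)ccc1Cc1nn(C)c2ccc(NC(=O)OC3CCCC3)cc12`: 0.3 nM

In an assay on lung parenchyma (Cavia porcellus) for displacement of a labelled ligand from cysteinyl leukotriene receptor (Homo sapiens) (a higher number here means a weaker inhibitor, a lower number a stronger inhibitor), compound 1 gives 0.8 nM, the highest number of the three; compound 2 and compound 3 both sit lower by a margin beyond the scatter. Compound 2 and compound 3 differ only in one place on the aromatic ring of the sulfonyl group, and that step, no change at the digits printed from compound 2 to compound 3 (within the scatter), shows the read-out indifferent to that exchange. Among the measured compounds shown here, compound 1 differs from both of them in more than one place, so no single step joins it to them.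

Compound 4, `COc1cc(C(=O)NS(=O)(=O)c2ccccc2)ccc1Cc1c[nH]c2ccc(NC(=O)OC3CCCC3)cc12`, is compound 1 with the change (hydrogen in place of methyl on an aromatic nitrogen). For the measured compounds named here, no measured pair shows what a hydrogen in place of a methyl on the aromatic nitrogen does in this assay; the only measured step concerns another part of the molecule. Going by the values given here, with no bearing step, the expected change is none beyond the scatter, and compound 4 is estimated at 1 nM (range 0.3 nM to 3 nM), which means an expected step of a 1.3-fold higher number from compound 1 to compound 4 (0.10 log units; within the scatter).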

Compound 4, inhibition constant: 1.4 nM
For compound 4 the middle estimate is 1.4-fold (0.15 log units) below the measured one, and the stated range covers the measured number.
By their numbers in this assay, from the lowest: compounds 2 and 3 (each within the scatter of the next); then compounds 1 and 4 (each within the scatter of the next).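

In this assay, among the compounds shown here, putting hydrogen in place of methyl on the aromatic nitrogen of the five-membered aromatic ring gives a 1.8-fold higher number from compound 1 to compound 4 (0.24 log units; within the scatter) at a position that no earlier step had touched. For this pair, then, the read-out does not depend on that methyl, and the nitrogen can carry a hydrogen with no change beyond the scatter. Nothing measured here accounts for this result.

The compounds shown leave open whether an ethyl group, a longer chain or a chain ending in a carboxylic acid on this nitrogen would also leave the read-out unchanged. They also leave open whether the same exchange would read alike in the core of compound 2 or compound 3.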